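The compounds below may be only part of what the source reports. "The series", "measured", "known", "first", "only" and "open" are said of these compounds alone.

Measured compounds:
compound 1, `[O-][S+](CCNC1CCN(CC(O)Cc2ccccc2)CC1)C(c1ccc(F)cc1)c1ccc(F)cc1`, 91.8 nM
compound 2, `O=C(c1cc2ccccc2o1)N1CCC(NCCSC(c2ccc(F)cc2)c2ccc(F)cc2)CC1`, 115 nM

Both were tested in an assay on membranes from striatum (strain Sprague-Dawley) for displacement of a labelled ligand from sodium-dependent dopamine transporter (Rattus norvegicus), read by scintillation counting, with a stated time of 120 min; a higher number here means a weaker inhibitor, a lower number a stronger inhibitor. Compound 1 gives 91.8 nM there, the lowest of the two numbers, while compound 2 gives 115 nM; the two values sit within the scatter of each other, so neither can be called the stronger inhibitor.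

Compound 3, `O=C(c1ccccc1F)N1CCC(NCC[S+]([O-])C(c2ccc(F)cc2)c2ccc(F)cc2)CC1`, has not been measured. It differs from compound 1 in one place: (2-fluorophenyl)carbonyl in place of 2-hydroxy-3-phenylpropyl on an amine nitrogen in a ring. Compound 2 likewise carries a carbonyl-linked aromatic group on the same ring nitrogen and comes out close to compound 1, which suggests that such an exchange on this nitrogen does not move the number far. The step from compound 1 to compound 3 is therefore expected to be small, possibly a modest weakening, and likely no further than the scatter, as a 1.4-fold higher number from compound 1 to compound 3 (0.15 log units; within the scatter). Compound 3 is expected to give 130 nM, within a range of 50 nM to 350 nM.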

Compound 3, inhibition constant: 604 nM
For compound 3 the middle estimate is 4.6-fold (0.67 log units) below the measured one; measured number outside the range, above it.
By their numbers in this assay, from the lowest: compounds 1 and 2 (each within the scatter of the next); then compound 3.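

In this assay, the amine nitrogen in the ring proves sensitive to what it carries: (2-fluorophenyl)carbonyl in place of 2-hydroxy-3-phenylpropyl gives a 6.6-fold higher number from compound 1 to compound 3 (0.82 log units; beyond the scatter), a step beyond the usual scatter. Compound 2 could not show this, as it differs from compound 1 in more than one place, so its close value was no clean test of the exchange. Nothing available explains the rise.

The exchange alters several things at once, including the hydroxyl, the carbonyl and the fluorine, so the shown compounds cannot assign the step to any one of them. A plain 3-phenylpropyl group without the hydroxyl, or an unsubstituted benzoyl group without the fluorine, would be needed to separate these parts.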